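Silicon-bound ring swapped: cyclohexyl replacing the phenol

A few compounds are considered here, and "the series" means these few. Any claim that something is new, unique, unknown or untested is made for them only; others in the source may bear on it.

Measured in a functional assay on liver (Sus scrofa) for inhibition of squalene monooxygenase (Homo sapiens), using microsomes; on this read-out higher numbers stand for weaker inhibition and lower numbers for stronger inhibition:
compound 1 `CCN(C/C=C/C#CC(C)(C)C)Cc1cccc(OC[Si](C)(C)c2ccc(O)cc2)c1` gives 8000 nM
compound 2 `CCN(C/C=C/C#CC(C)(C)C)Cc1cccc(OC[Si](C)(C)c2ccc(S)cc2)c1` gives 8000 nM
compound 3 `CCN(C/C=C/C#CC(C)(C)C)Cc1cccc(OC[Si](C)(C)c2ccc(C(=O)C(F)(F)F)cc2)c1` gives 5000 nM

Compound 1 stands level with compound 2, the two highest numbers of the three; the step of no change at the digits printed from compound 1 to compound 2 (within the scatter) and the step of a 1.6-fold lower number from compound 1 to compound 3 (0.20 log units; within the scatter) both stay inside the scatter, as does a 1.6-fold lower number from compound 2 to compound 3 (0.20 log units; within the scatter). Compound 4 `CCN(C/C=C/C#CC(C)(C)C)Cc1cccc(OC[Si](C)(C)C2CCCCC2)c1` differs from compound 1 in one place: cyclohexyl in place of 4-hydroxyphenyl on a silicon. The measured steps only exchange the group on that aromatic ring, never the ring itself, so they bear on this change loosely; they do show that varied groups at this end leave this assay unchanged. Compound 4 is therefore expected to sit close to compound 1, with a 1.1-fold lower number from compound 1 to compound 4 (0.06 log units; within the scatter). The estimate for compound 4 is 7000 nM, ranging from 2500 nM to 20000 nM.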

Compound 4, half-maximal inhibitory concentration: 20000 nM
Estimate against measurement, compound 4: 2.9-fold (0.46 log units) below; the measured number falls inside the stated range.
By their numbers in this assay, from the lowest: compounds 3, 1 and 2 (each within the scatter of the next); then compound 4.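

In this assay, the ring on the silicon proves more sensitive than the groups it carries: changing those groups stayed within the scatter, whereas cyclohexyl gives a 2.5-fold higher number from compound 1 to compound 4 (0.40 log units; beyond the scatter), a 2.5-fold higher number from compound 2 to compound 4 (0.40 log units; beyond the scatter) and a 4.0-fold higher number from compound 3 to compound 4 (0.60 log units; beyond the scatter). No measurement here explains this rise.

The change removes the aromatic ring and its group together, so the effect of each alone stays unresolved. As far as these compounds go, whether plain phenyl would keep the lower numbers, and how cyclopentyl or a butyl chain would fare on the silicon, remains open.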